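Lengthening a Branched Chain on the Shared Core

The source may report more compounds than this note shows. Statements on the series, on what has been measured and on what is new or still open speak of the compounds shown alone.

Of the compounds shown here, three with a shared core have been measured in a functional assay on HL-60 cells (Homo sapiens) for inhibition, read by MTT assay, with a stated time of 72 h; on this read-out higher numbers stand for weaker inhibition and lower numbers for stronger inhibition. Compound 2 `COc1cccc(N2CCN(C(=O)c3oc(C)nc3-c3ccccc3F)CC2)c1` gives 56.1 nM. Compound 1 `CCc1nc(-c2cccc(F)c2)c(C(=O)N2CCN(c3cccc(OC)c3)CC2)o1` gives 201 nM. Compound 3 `CCc1nc(-c2ccc(C(C)C)cc2)c(C(=O)N2CCN(c3cccc(OC)c3)CC2)o1` gives 887 nM, the highest of the three numbers and so the weakest inhibitor among them. Going by the values given here, the one measured step that reaches compound 3 is a 4.4-fold higher number from compound 1 to compound 3 (0.64 log units; beyond the scatter), from 4-isopropylphenyl in place of 3-fluorophenyl on an aromatic carbon.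

Compound 4 `CCc1nc(-c2ccc(C(C)(C)C)cc2)c(C(=O)N2CCN(c3cccc(OC)c3)CC2)o1` differs from compound 3 by methyl in place of hydrogen on a saturated chain carbon bound to an aromatic carbon and two saturated chain carbons; cut one bond further out, the change reads isopropyl to tert-butyl, or 4-isopropylphenyl to 4-(tert-butyl)phenyl. Among the compounds with values here, no measured step adds a methyl at such a place, so the direction is uncertain. The step from compound 1 to compound 3 shows that the last change here gave a higher number, and further growth of the same chain is expected to move the number little or somewhat higher, giving a 1.4-fold higher number from compound 3 to compound 4 (0.13 log units; within the scatter). Compound 4 is therefore estimated at 1200 nM, with a range from 500 nM to 3000 nM.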

Compound 4, half-maximal inhibitory concentration: "not active" (no number reported)
For compound 4 the study gives words and no number, so the estimate cannot be set against anything.
By their numbers in this assay, from the lowest: compound 2; then compound 1; then compound 3.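

Going by these compounds alone, compound 4 is reported only in words, as not active, so no step from compound 3 can be read. The compounds shown leave open how far isopropyl to tert-butyl moves the number. Nothing available here bears on this result.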